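A few compounds are considered here, and "the series" means these few. Any claim that something is new, unique, unknown or untested is made for them only; others in the source may bear on it.

In a functional assay on HepG2 cells (Homo sapiens) for inhibition, read by MTT assay, with a stated time of 3 days (a higher number here means a weaker inhibitor, a lower number a stronger inhibitor), three compounds that share one core have been measured. Compound 1 `COc1cc(-c2nc3ccccc3s2)ccc1OCC(=O)NNC(=O)CCl` gives 2890 nM, compound 2 `CC[C@H](C)[C@@H](NCC(=O)NNC(=O)COc1ccc(-c2nc3ccccc3s2)cc1OC)C(=O)O` gives 3990 nM, and compound 3 `COc1cc(-c2nc3ccccc3s2)ccc1OCC(=O)NNC(=O)CN[C@@H](CS(=O)(=O)O)C(=O)O` gives 3690 nM. Compound 3 therefore stands within the scatter of both other compounds, and the three numbers cannot be ranked.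

Compound 4 `COc1cc(-c2nc3ccccc3s2)ccc1OCC(=O)NNC(=O)CN[C@@H](CCSC)C(=O)O` differs from compound 3 in one place: (methylsulfanyl)methyl in place of sulfo on a saturated chain carbon, two bonds along the chain from an amine nitrogen and a carbonyl carbon. Put simply, (methylsulfanyl)methyl takes the place of sulfo, turning 1-carboxy-2-sulfoethyl into 1-carboxy-3-(methylsulfanyl)propyl on the amine nitrogen.

Among the compounds with values here, three measured steps bear on this change. Replacing chloro with (1-carboxy-2-methylbutyl)amino gave a 1.4-fold higher number from compound 1 to compound 2 (0.14 log units; within the scatter), and replacing it with (1-carboxy-2-sulfoethyl)amino gave a 1.3-fold higher number from compound 1 to compound 3 (0.11 log units; within the scatter). Within the data shown here, the closest precedent is the exchange of one group on the amine nitrogen for another, which gave a 1.1-fold lower number from compound 2 to compound 3 (0.03 log units; within the scatter). On the strength of these three small steps, no step beyond the scatter is expected in this assay. The expected change is a 1.1-fold lower number from compound 3 to compound 4 (0.02 log units; within the scatter). Compound 4 is estimated at 3500 nM, with an expected range from 1800 nM to 6500 nM.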

Compound 4, half-maximal inhibitory concentration: 3780 nM
For compound 4 the middle estimate is 1.1-fold (0.03 log units) below the measured one; the measured number falls inside the stated range.
By their numbers in this assay, from the lowest: compounds 1, 3, 4 and 2 (each within the scatter of the next).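

Putting (methylsulfanyl)methyl in place of sulfo on this saturated chain carbon gives a 1.0-fold higher number from compound 3 to compound 4 (0.01 log units; within the scatter) in this assay, so at this position a group without the hydrogen-bond donor of sulfo gives a number within the scatter of the sulfo compound. The other two new steps also stay within the scatter, with a 1.1-fold lower number from compound 2 to compound 4 (0.02 log units; within the scatter) and a 1.3-fold higher number from compound 1 to compound 4 (0.12 log units; within the scatter), so all four compounds now read alike whichever of these groups sits at the end of the chain. No independent evidence bears on why this change leaves the number within the scatter.

Still open, from the compounds shown here alone, is whether any group here can move the number beyond the scatter, such as a carboxylic acid in place of sulfo, a longer chain ending in an amine, or a phenyl ring. The compounds shown all keep the shared core, so they leave open how changes to that core would read in this assay.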